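Nitro entering the benzyloxy ring: expected effect on compound 4

The compounds below may be only part of what the source reports. "The series", "measured", "known", "first", "only" and "open" are said of these compounds alone.

Measured so far:
compound 1 `CS(=O)(=O)OCC1CN(S(C)(=O)=O)c2cc(OCc3ccccc3)ccc21`: 4.39 ug/mL in a functional assay on KB cells (Homo sapiens), read by crystal violet staining; a lower number here means a stronger inhibitor, a higher number a weaker inhibitor
compound 2 `CS(=O)(=O)N1CC(CCl)c2ccc(OCc3ccccc3)cc21`: 6.32 ug/mL in this assay
compound 3 `COC(=O)c1cc2c(cc1OCc1ccccc1)N(S(C)(=O)=O)CC2CCl`: 7.14 ug/mL in this assay

Compound 1 holds the lowest of the three numbers, yet the step to compound 2 is a 1.4-fold higher number from compound 1 to compound 2 (0.16 log units; within the scatter), and compound 3 sits within the scatter of compound 1 as well, so the three are not separated. Compound 4 `CS(=O)(=O)OCC1CN(S(C)(=O)=O)c2cc(OCc3ccccc3)c([N+](=O)[O-])cc21` differs from compound 1 by nitro in place of hydrogen on an aromatic carbon. For the measured compounds named here, the one measured change on an aromatic carbon is a 1.1-fold higher number from compound 2 to compound 3 (0.05 log units; within the scatter), within the scatter; no measured step involves a nitro group. On that single precedent, compound 4 is expected to show no step beyond the scatter, a 1.0-fold higher number from compound 1 to compound 4 (0.01 log units; within the scatter). The estimate for compound 4 in this assay is 4.5 ug/mL, with a range from 2 ug/mL to 10 ug/mL.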

Compound 4, half-maximal inhibitory concentration: 7.91 ug/mL
Compound 4: the middle estimate sits 1.8-fold (0.24 log units) below what was measured; the measured number falls inside the stated range.
By their numbers in this assay, from the lowest: compounds 1, 2, 3 and 4 (each within the scatter of the next).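

In this assay, nitro on the aromatic carbon ortho to a benzyloxy group gives a 1.8-fold higher number from compound 1 to compound 4 (0.26 log units; within the scatter), so a nitro group at this position leaves the compound within the scatter of compound 1. The step is read with (methylsulfonyl)oxy on the saturated chain, while a 1.1-fold higher number from compound 2 to compound 3 (0.05 log units; within the scatter) is read with chloro there. No supporting measurement bears on the reason for this result.

From the compounds shown here alone, whether an amine or a carboxylic acid on this aromatic carbon would give a step beyond the scatter remains open. Also open, going by these compounds, is how nitro behaves with chloro on the saturated chain.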